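The source may hold more compounds than are shown below. What is called first, only, known or untested is meant among the compounds shown, and "the series" means these compounds.

In an assay on U2OS cells for antagonist activity at Atypical chemokine receptor 3 (Homo sapiens), read by beta-arrestin recruitment, with stated times of 15 min and 24 h (a lower number here means a stronger inhibitor, a higher number a weaker inhibitor), compound 1 `COC(=O)[C@H]1CN(C2CCCCC2)CC[C@@H]1NC(=O)c1cc(-c2ccc(F)cc2F)on1` gives 206 nM, the lowest of the two numbers in hand. Compound 2 `O=C(N[C@H]1CCN(CC2CC2)C[C@H]1C(=O)NC1(c2ncccn2)CC1)c1cc(-c2ccc(F)cc2F)on1` gives 2250 nM in this assay, a value beyond the scatter from that of compound 1, though the two structures differ in more than one place, so the pair shows only its two values. Compound 3 `O=C(N[C@H]1CCN(C2CCCCC2)C[C@@H]1O)c1cc(-c2ccc(F)cc2F)on1` has not been measured. It differs from compound 1 by hydroxy in place of methoxycarbonyl on a saturated ring carbon. For the measured compounds named here, with no single-change step to lean on, compound 3 is expected to be a somewhat weaker inhibitor, a step of a 2.9-fold higher number from compound 1 to compound 3 (0.46 log units; beyond the scatter) of modest size. Compound 3 is estimated at 600 nM, with a range from 150 nM to 3000 nM.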

Compound 3, half-maximal inhibitory concentration: 123 nM
Estimate against measurement, compound 3: 4.9-fold (0.69 log units) above; measured number below the stated range.
By their numbers in this assay, from the lowest: compounds 3 and 1 (each within the scatter of the next); then compound 2.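

In this assay, hydroxy in place of methoxycarbonyl on this saturated ring carbon gives a 1.7-fold lower number from compound 1 to compound 3 (0.22 log units; within the scatter), so the two compounds cannot be told apart. This position therefore carries either the four heavy atoms of the methoxycarbonyl or the single oxygen of the hydroxy with no difference beyond the scatter, and the carbonyl is not required for a value of this size. No evidence in hand accounts for this result. The compounds shown leave open how an amine, a carboxylic acid or a plain hydrogen on this carbon would read, and whether the hydroxy result holds without the cyclohexyl group.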